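Working notes: from compound 3 to compound 4

This account rests on a few compounds, and the source may have more. Where it says the series, first, only, none or still open, it means among the compounds named here.

Measured so far:
compound 1 `Clc1ccc(-c2cc(-c3ccsc3)nc(-c3ccco3)c2)o1` gives 8.2% in an assay on isolated protein for inhibition of DNA topoisomerase 1 (Homo sapiens), tested at 100 uM; on this read-out lower numbers stand for a weaker effect and higher numbers for a stronger effect at the one concentration tested
compound 2 `Clc1ccc(-c2cc(-c3ccsc3)nc(-c3ccccc3Cl)c2)o1` gives 0% in this assay
compound 3 `Clc1ccc(-c2cc(-c3ccc(Cl)o3)cc(-c3ccsc3)n2)cc1` gives 29.8% in this assay

Compound 3 stands highest of the three, with compound 1 nearest and compound 2 furthest; the steps of a number 21.6 percentage points higher from compound 1 to compound 3 (beyond the scatter) and a number 29.8 percentage points higher from compound 2 to compound 3 (beyond the scatter) are both beyond the scatter, whereas a number 8.2 percentage points lower from compound 1 to compound 2 (within the scatter) is within it. Compound 4 `Cc1ccc(-c2cc(-c3ccc(Cl)o3)cc(-c3ccsc3)n2)o1` differs from compound 3 in one place: 5-methylfuran-2-yl in place of 4-chlorophenyl on an aromatic carbon. The step that bears on this is the reverse of a number 21.6 percentage points higher from compound 1 to compound 3 (beyond the scatter), since compound 1 carries furan-2-yl where compound 4 carries 5-methylfuran-2-yl; nothing measured shows what the added methyl does. In this assay a modest fall is therefore expected, about a number 17.8 percentage points lower from compound 3 to compound 4 (beyond the scatter). Compound 4 is estimated at 12%, within 0% to 30%.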

Compound 4, a percentage reported as inhibition, at one concentration (the size of the read-out at that concentration, not a potency): 9.1%
The estimate for compound 4 lay 2.9 percentage points above the measured number; low and high end bracket the measured number.
By their numbers in this assay, from the lowest: compounds 2, 1 and 4 (each within the scatter of the next); then compound 3.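

In this assay, a second five-membered aromatic ring at this carbon next to the ring nitrogen does not match 4-chlorophenyl, with a number 20.7 percentage points lower from compound 3 to compound 4 (beyond the scatter). Adding methyl to the furan gives no readable change, with a number 0.9 percentage points higher from compound 1 to compound 4 (within the scatter), and 5-methylfuran-2-yl is not separated from 2-chlorophenyl, with a number 9.1 percentage points higher from compound 2 to compound 4 (within the scatter). No evidence on hand accounts for these differences.

Open, on these data alone, is whether an amine or a carboxylic acid on the phenyl ring at this carbon would keep the effect seen for compound 3 at 29.8%. Also open, as far as these compounds go, is what replacing the 5-chlorofuran-2-yl or thiophen-3-yl group would do.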